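The compounds below may be only part of what the source reports. "The series", "measured", "known", "first", "only" and "open" are said of these compounds alone.

Measured in a functional assay on SGC-7901 cells (Homo sapiens) for cytotoxicity, read by MTT assay, with a stated time of 48 h; a higher number here means a weaker inhibitor, a lower number a stronger inhibitor:
compound 1 `Cc1ccccc1-c1nnc(SCCn2c([N+](=O)[O-])cnc2C)o1`: 32300 nM
compound 2 `Cc1ncc([N+](=O)[O-])n1CCSc1nnc(-c2ccc([N+](=O)[O-])cc2)o1`: 12200 nM

Of the two, compound 2 holds the lower number, 12200 nM, which makes it the stronger inhibitor in this assay, and its gap to compound 1 lies beyond the usual scatter. Compound 3 `Cc1ncc([N+](=O)[O-])n1CCSc1nnc(-c2ccc(Cl)cc2)o1` has not yet been measured. It departs from compound 2 at a single place, with chloro in place of nitro on an aromatic carbon. Going by the values given here, no measured pair isolates this swap, so the expectation rests only on the spread seen so far, from compound 2 at 12200 nM to compound 1 at 32300 nM. No step beyond the scatter is expected, and no firm direction can be given, though a slightly higher number is estimated: a 1.1-fold higher number from compound 2 to compound 3 (0.06 log units; within the scatter). In this assay, compound 3 is expected at 14000 nM, with an estimated range from 5000 nM to 40000 nM.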

Compound 3, half-maximal inhibitory concentration: 31900 nM
Estimate against measurement, compound 3: 2.3-fold (0.36 log units) below; measured number inside the range.
By their numbers in this assay, from the lowest: compound 2; then compounds 3 and 1 (each within the scatter of the next).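

In this assay, going by these compounds alone, chloro in place of nitro on an aromatic carbon para to a large group gives a 2.6-fold higher number from compound 2 to compound 3 (0.42 log units; beyond the scatter) as a modest step, the first single-place change at this position that can be read, and it shows that the number responds to the group held there. With 4-chlorophenyl in place of 2-methylphenyl the result is a 1.0-fold lower number from compound 1 to compound 3 (0.01 log units; within the scatter) and the two compounds cannot be told apart, so among the three only compound 2, with nitro on this ring, stands apart. No measurement at hand accounts for the step from nitro to chloro.

On these data alone, whether an amine, a methoxy group or a carboxylic acid at this position would match nitro or go beyond it remains open. So does whether a longer chain in place of the thioethyl link would alter the number at all.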